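From a methoxy to a methylsulfanyl oxazole

The source may report more compounds than this note shows. Statements on the series, on what has been measured and on what is new or still open speak of the compounds shown alone.

Three ketones sharing one core have been measured in an assay on HEK-293T cells for inhibition of diacylglycerol lipase-alpha (Homo sapiens), read by colorimetric assay; on this read-out higher numbers stand for weaker inhibition and lower numbers for stronger inhibition. Compound 1 `CS(=O)(=O)c1coc(C(=O)CCCCCCc2ccccc2)n1` gives 389 nM. Compound 2 `CC(C)(C)C(=O)c1coc(C(=O)CCCCCCc2ccccc2)n1` gives 479 nM, and the change a 1.2-fold higher number from compound 1 to compound 2 (0.09 log units; within the scatter) stays within the scatter. Compound 3 `COc1coc(C(=O)CCCCCCc2ccccc2)n1` reaches only a limit, > 10000 nM, so no number is known for it. It stands at the weak end of the three: the steps of an at least 25-fold higher number from compound 1 to compound 3 (1.41 log units; beyond the scatter) and an at least 20-fold higher number from compound 2 to compound 3 (1.31 log units; beyond the scatter) are both large, and both end at the limit of > 10000 nM in this assay, at which 1 of the 3 values shown sits.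

Compound 4 `CSc1cnc(C(=O)CCCCCCc2ccccc2)o1` has not been measured. It differs from compound 3 in one place: 5-(methylsulfanyl)-1,3-oxazol-2-yl in place of 4-methoxy-1,3-oxazol-2-yl on a carbonyl carbon. The measured steps that bear on this change are the two leading into compound 3, where methoxy replaced methylsulfonyl or (tert-butyl)carbonyl and the number rose beyond the scatter. Methylsulfanyl is neither of those groups, so the step from compound 3 is expected to be a modest gain at best, an at least 2.0-fold lower number from compound 3 to compound 4 (0.30 log units; that floor lies within the scatter). Compound 4 is estimated at 5000 nM, within a range from 1000 nM to 20000 nM, with a real chance that only a limit is reported again.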

Compound 4, half-maximal inhibitory concentration: > 10000 nM
Compound 4 ended at the assay's limit (the forecaster's own chance of this, stated with the estimate: 45%); middle value at least 2.0-fold (0.30 log units) away from the limit.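

Compound 3 and compound 4 both end at a limit of the assay rather than a number, and the step between them cannot be read. Going by these compounds, whether 5-(methylsulfanyl)-1,3-oxazol-2-yl inhibits more or less strongly than 4-methoxy-1,3-oxazol-2-yl on this core stays open.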